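Chloro additions in a thiazole-imine series: cytotoxicity notes

This account rests on a few compounds, and the source may have more. Where it says the series, first, only, none or still open, it means among the compounds named here.

Measured compounds:
- compound 1, `Oc1ccccc1/C=N/c1sc2c(c1-c1nc3ccccc3s1)CCC2`: 100 ug/mL
- compound 2, `Clc1ccc(/C=N/c2sc3c(c2-c2nc4ccccc4s2)CCCC3)c(Cl)c1`: 56.6 ug/mL
- compound 3, `Clc1ccccc1/C=N/c1sc2c(c1-c1nc3ccccc3s1)CCCC2`: 332 ug/mL

In an ADME assay on cells (Rhabdomyosarcoma cell, Homo sapiens) for cytotoxicity, read by MTT assay, with a stated time of 72 h (on this read-out higher numbers stand for lower toxicity in this test and lower numbers for higher toxicity in this test), compound 1 gives 100 ug/mL, compound 2 gives 56.6 ug/mL and compound 3 gives 332 ug/mL. Compound 1 and compound 2 sit within the scatter of each other, so no order between them is claimed; compound 3 stands apart from both, beyond the scatter.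

The one measured step in this assay is a 5.9-fold lower number from compound 3 to compound 2 (0.77 log units; beyond the scatter), the change being chloro in place of hydrogen on an aromatic carbon
The step from compound 1 to compound 4 is of the same kind: chloro in place of hydrogen on an aromatic carbon
The two places differ, however: in compound 2 the entering chloro sits meta to a chloro group and para to a large group, whereas in compound 4 it sits on a ring that is part of a fused system of two rings, meta to a fused ring and para to a fused ring. The difference between the core of compound 1 and the core of compound 3 is not broken down here.

Compound 4, `Oc1ccccc1/C=N/c1sc2c(c1-c1nc3cc(Cl)ccc3s1)CCC2`, is yet to be measured in this assay. Its estimate rests on a single measured step of the same kind at a different place, so the expected step from compound 1 to compound 4 is set smaller, with wide bounds, than the step measured from compound 3 to compound 2 a 5.9-fold lower number from compound 3 to compound 2 (0.77 log units; beyond the scatter). The expected step is a 2.0-fold lower number from compound 1 to compound 4 (0.30 log units; within the scatter). For compound 4 the estimated value is 50 ug/mL, expected to fall between 15 ug/mL and 160 ug/mL.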

Compound 4, half-maximal cytotoxic concentration: 269 ug/mL
The estimate for compound 4 lay 5.4-fold (0.73 log units) below the measured number; measured number outside the range, above it.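

In this assay, chloro in place of hydrogen on an aromatic carbon, here on a six-membered ring that is part of a fused system of two rings, gives a 2.7-fold higher number from compound 1 to compound 4 (0.43 log units; beyond the scatter), which runs opposite to a 5.9-fold lower number from compound 3 to compound 2 (0.77 log units; beyond the scatter). The change therefore does not carry from one core to another in this series with a fixed size or even a fixed direction: the same change on two cores in this assay, a 5.9-fold lower number (0.77 log units; beyond the scatter) from compound 3 to compound 2 and a 2.7-fold higher number (0.43 log units; beyond the scatter) from compound 1 to compound 4, 16-fold (1.20 log units) apart, beyond the scatter of two such steps

This does not show that the core alone sets the outcome, since the chloro enters at a different place in each step, on a different ring, so the effects of core and place cannot be separated, and two steps give no rule for any further compound in the series.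

The compounds shown leave open whether chloro on the fused ring would raise the number on the core of compound 3 as it does on the core of compound 1, and whether chloro placed as in compound 2 would lower it on the core of compound 1. They also leave open how other groups at the place taken by chloro in compound 4, such as methoxy, an amine or a carboxylic acid, would behave in this assay.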